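From furan-2-yl back to a halogenated phenyl amide

The source may report more compounds than this note shows. Statements on the series, on what has been measured and on what is new or still open speak of the compounds shown alone.

Among the measured compounds shown here, compound 3 `CCN1CCN(c2cc(C)c3cc(NC(=O)c4ccco4)ccc3n2)CC1` gives 37500 nM in a functional assay on SK-BR-3 cells (Homo sapiens) for antiproliferative activity, read by MTT assay, with a stated time of 72 h (a lower number here means a stronger inhibitor, a higher number a weaker inhibitor), the highest of the three numbers measured so far: compound 1 `CCN1CCN(c2cc(C)c3cc(NC(=O)c4ccc(Cl)cc4)ccc3n2)CC1` gives 3020 nM and compound 2 `CCN1CCN(c2cc(C)c3cc(NC(=O)c4cc(Cl)cc(Cl)c4)ccc3n2)CC1` gives 2660 nM. Compound 4 `CCN1CCN(c2cc(C)c3cc(NC(=O)c4ccc(F)c(F)c4)ccc3n2)CC1` has not yet been measured; it differs from compound 3 by 3,4-difluorophenyl in place of furan-2-yl on a carbonyl carbon. For the measured compounds named here, two measured steps bear on this change, both running the other way: a 12-fold higher number from compound 1 to compound 3 (1.09 log units; beyond the scatter) and a 14-fold higher number from compound 2 to compound 3 (1.15 log units; beyond the scatter), whereas a 1.1-fold lower number from compound 1 to compound 2 (0.06 log units; within the scatter). Since the 3,4-difluorophenyl entering compound 4 is, like the chlorophenyl groups of compounds 1 and 2, a six-membered aromatic ring of carbon only, compound 4 is expected to fall back toward those two compounds, a step of an 11-fold lower number from compound 3 to compound 4 (1.03 log units; beyond the scatter). Compound 4 is therefore estimated at 3500 nM, within a range from 1500 nM to 9000 nM.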

Compound 4, half-maximal inhibitory concentration: 1980 nM
For compound 4 the middle estimate is 1.8-fold (0.25 log units) above the measured one, and the stated range covers the measured number.
By their numbers in this assay, from the lowest: compounds 4, 2 and 1 (each within the scatter of the next); then compound 3.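

In this assay fluorine on the phenyl ring serves as well as chlorine: there is a 19-fold lower number from compound 3 to compound 4 (1.28 log units; beyond the scatter) and the new compound sits with the chlorinated amides, with a 1.3-fold lower number from compound 2 to compound 4 (0.13 log units; within the scatter) and a 1.5-fold lower number from compound 1 to compound 4 (0.18 log units; within the scatter) as the steps that place it there. Three different halogen patterns on the phenyl ring thus give numbers within the scatter of one another, and only the furan-2-yl amide, compound 3, stands apart. Nothing given here accounts for that separation. On these data alone, whether an unsubstituted phenyl or a pyridine ring on this carbonyl carbon would stay with the halogenated amides remains open, as does whether a thiophene would follow the furan-2-yl.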